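Working notes: tert-butyl to chloro in the series

This account rests on a few compounds, and the source may have more. Where it says the series, first, only, none or still open, it means among the compounds named here.

Measured in a functional assay on A549 cells (Homo sapiens) for cytotoxicity, read by MTT assay, with a stated time of 48 h; on this read-out lower numbers stand for stronger inhibition and higher numbers for weaker inhibition:
compound 1 `C=C(c1ccc(OC)cc1)c1cc(OC)c(OC)c(OC)c1-c1ccc(OC)cc1`: 14000 nM
compound 2 `C=C(c1ccc(OC)cc1)c1cc(OC)c(OC)c(OC)c1-c1ccccc1`: 22000 nM
compound 3 `C=C(c1ccc(OC)cc1)c1cc(OC)c(OC)c(OC)c1-c1ccc(C(C)(C)C)cc1`: 27000 nM

Compound 3 stands within the scatter of both other measured compounds, as a 1.2-fold higher number from compound 2 to compound 3 (0.09 log units; within the scatter) and a 1.9-fold higher number from compound 1 to compound 3 (0.29 log units; within the scatter) show. Neither step separates it from the rest of the set.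

The next compound is compound 4 `C=C(c1ccc(OC)cc1)c1cc(OC)c(OC)c(OC)c1-c1ccc(Cl)cc1`, which carries chloro in place of tert-butyl on an aromatic carbon. Going by the values given here, no chloro compound has been measured yet, so the evidence is indirect. The closest guide is the three steps that exchange the group on this same aromatic carbon. These are the two above and a 1.6-fold higher number from compound 1 to compound 2 (0.20 log units; within the scatter), and all three stay within the scatter.

On that basis, no step beyond the scatter is expected in this assay, and no firm direction can be assigned. The estimated step is a 1.4-fold lower number from compound 3 to compound 4 (0.15 log units; within the scatter). For compound 4 the expected value is 19000 nM, with an estimated range of 9500 nM to 36000 nM.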

Compound 4, half-maximal inhibitory concentration: 29000 nM
Beside the measured number, compound 4's estimate is 1.5-fold (0.18 log units) below it, and the stated range covers the measured number.
By their numbers in this assay, from the lowest: compounds 1, 2, 3 and 4 (each within the scatter of the next, the first and the last beyond it).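

In this assay, exchanging tert-butyl for chloro on this aromatic carbon produces no readable shift, with a 1.1-fold higher number from compound 3 to compound 4 (0.03 log units; within the scatter) and, against the hydrogen compound, a 1.3-fold higher number from compound 2 to compound 4 (0.12 log units; within the scatter) as the two steps, so chloro joins hydrogen and tert-butyl as a group that cannot be told apart from its neighbours in the series. Going by these compounds alone, the first step beyond the scatter in the set comes with chloro in place of methoxy, where a 2.1-fold higher number from compound 1 to compound 4 (0.32 log units; beyond the scatter) marks a modest gap, and the steps from compound 1 to compound 2 and to compound 3 do not reach that size. No supporting data are available to explain these numbers.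

Going by these compounds, whether an amine, a hydroxyl or a carboxylic acid on this carbon would give a clear step away from the methoxy compound stays open. On these data alone, it also stays open whether the modest gap between compound 1 and compound 4 would hold up on repeat measurement or in other cell lines.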